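A few compounds are considered here, and "the series" means these few. Any claim that something is new, unique, unknown or untested is made for them only; others in the source may bear on it.

Of the compounds shown here, three with one shared core have been measured in an assay with 3-hydroxy-3-methylglutaryl-coenzyme A reductase (Rattus norvegicus) as the target; on this read-out lower numbers stand for stronger inhibition and higher numbers for weaker inhibition. Compound 1 `CCC(C)(C)C(=O)O[C@H]1C[C@H](C)[C@@H](O)[C@@H]2CC[C@H](C)[C@H](CC[C@@H]3C[C@@H](O)CC(=O)O3)C12` gives 48.6 nM. Compound 2 `CCC(C)(C)C(=O)O[C@H]1C[C@H](C)[C@H](O)[C@@H]2CC[C@H](C)[C@H](CC[C@@H]3C[C@@H](O)CC(=O)O3)C12`, which differs from it only in the drawn configuration of one ring carbon, gives 289 nM, a step of a 5.9-fold higher number from compound 1 to compound 2 (0.77 log units; beyond the scatter). Compound 3 `CCC(C)(C)C(=O)O[C@H]1C[C@@H](C)[C@@H](O)[C@@H]2CC[C@H](C)[C@H](CC[C@@H]3C[C@@H](O)CC(=O)O3)C12` differs from compound 1 in the configuration of a different ring carbon. In this assay compound 3 gives 40.8 nM; the step of a 1.2-fold lower number from compound 1 to compound 3 (0.08 log units; within the scatter) lies within the scatter, so compound 3 and compound 1 cannot be told apart, while the step of a 7.1-fold lower number from compound 2 to compound 3 (0.85 log units; beyond the scatter) is a clear one.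

Compound 4 `CCC(C)(C)C(=O)O[C@H]1C[C@@H](C)[C@@H](OC(=O)NCc2ccccc2)[C@@H]2CC[C@H](C)[C@H](CC[C@@H]3C[C@@H](O)CC(=O)O3)C12` is not yet measured. It carries the change benzylcarbamoyl in place of hydrogen on an oxygen on a saturated carbon: the free hydroxy on the core becomes a (benzylcarbamoyl)oxy group, bringing in a six-membered aromatic ring, one hydrogen-bond donor and one acceptor. None of the three measured steps adds or removes any atoms; all three only turn a stereocentre, and their sizes ranged from within the scatter to modest. Within the data shown here, there is therefore no measured step that speaks to this kind of change, and the expectation can only be loose. In this assay compound 4 is expected to give about 90 nM, somewhere between 20 nM and 500 nM, a step of a 2.2-fold higher number from compound 3 to compound 4 (0.34 log units; beyond the scatter) that is estimated as slightly weakening at most.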

Compound 4, half-maximal inhibitory concentration: 5 nM
Compound 4: middle estimate off by 18-fold (1.26 log units), on the high side, outside the stated range (below it).
By their numbers in this assay, from the lowest: compound 4; then compounds 3 and 1 (each within the scatter of the next); then compound 2.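

In this assay, the free hydroxy on the shared core does not have to stay free: turning it into a (benzylcarbamoyl)oxy group gives an 8.2-fold lower number from compound 3 to compound 4 (0.91 log units; beyond the scatter). Among these compounds, all the earlier steps only turned a stereocentre and added no atoms, so this is the first sign that the oxygen on this saturated carbon can carry a substantial group, here of 10 heavy atoms including a six-membered aromatic ring, and that the inhibition read-out gets stronger rather than weaker with it. This rests on a single pair of compounds, and nothing measured here accounts for why the change lowers the number.

The compounds shown leave open which part of the new group goes with this step, the six-membered aromatic ring or the carbamoyl unit, a question that a methylcarbamoyl or an acetyl group on the same oxygen, or a longer chain such as phenethylcarbamoyl, would help to settle. As far as these compounds go, it also remains open whether the same (benzylcarbamoyl)oxy group would give a similar step on the core of compound 1 or of compound 2, which differ from compound 3 in their drawn configuration.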